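Shortening the Chain from Compound 2 to Compound 3

The compounds below may be only part of what the source reports. "The series", "measured", "known", "first", "only" and "open" are said of these compounds alone.

Among the compounds with values here, compound 2 `CCCCCCCCCCc1cccc(N2CCNCC2)n1` gives 30 mg/kg in a functional assay on the whole organism with Mus musculus as the target, in the maximal electroshock model, with a stated time of 120 min (on this read-out higher numbers stand for an effect only at larger amounts of compound and lower numbers for an effect already at smaller amounts), the highest of the two numbers measured so far. Its nearest neighbour, compound 1 `CCCCCCCCCc1cccc(N2CCNCC2)n1`, gives 10 mg/kg in this assay. Within the data shown here, the single measured step, a 3.0-fold higher number from compound 1 to compound 2 (0.48 log units; beyond the scatter), came with the methyl in place of hydrogen on a saturated chain carbon, nine bonds along the chain from an aromatic carbon.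

Compound 3 `CCCCCCCCc1cccc(N2CCNCC2)n1` differs from compound 2 by hydrogen in place of ethyl on a saturated chain carbon, eight bonds along the chain from an aromatic carbon. Among the measured compounds shown here, this change runs opposite to the measured step and reaches further, so the one step that bears on it points toward a lower number. The expectation rests on compound 1 because a 3.0-fold higher number from compound 1 to compound 2 (0.48 log units; beyond the scatter) rose as the chain grew; whether shortening below compound 1 continues that course is not known from two compounds, so the range is kept wide. Compound 3 is therefore expected to give 6 mg/kg in this assay, between 2 mg/kg and 20 mg/kg, an estimated step of a 5.0-fold lower number from compound 2 to compound 3 (0.70 log units; beyond the scatter).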

Compound 3, minimum effective dose: 10 mg/kg
For compound 3 the middle estimate is 1.7-fold (0.22 log units) below the measured one; measured number inside the range.
By their numbers in this assay, from the lowest: compounds 1 and 3 (each within the scatter of the next); then compound 2.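

In this assay, within the data shown here, the loss of ethyl at this place, on a saturated chain carbon, eight bonds along the chain from an aromatic carbon, brings a 3.0-fold lower number from compound 2 to compound 3 (0.48 log units; beyond the scatter), so the number responds to this change as well as to the single step seen before. The smaller change at the same place, hydrogen in place of methyl, brings no change at the digits printed from compound 1 to compound 3 (within the scatter), which means that of the three compounds only compound 2 stands apart and that the shift seen on lengthening the chain does not continue on shortening it. No measurement offered here accounts for this result.

On these data alone, whether a hexyl chain or a longer chain than that of compound 2 would fit this picture stays open. So does the effect of an amine or a carboxylic acid in place of the chain.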